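The source may hold more compounds than are shown below. What is called first, only, known or untested is meant among the compounds shown, and "the series" means these compounds.

Compound 1 `CCOC(=O)[C@@H]1CCCN(S(=O)(=O)c2ccc(S(=O)(=O)N3CCOCC3)cc2)C1`: in a functional assay on MIA PaCa-2 cells (Homo sapiens) for inhibition, read by MTT assay, with a stated time of 3 days (on this read-out lower numbers stand for stronger inhibition and higher numbers for weaker inhibition), compound 1 gives > 10000 nM, which is a limit of the assay.
Compound 2 `CCN(CC)S(=O)(=O)c1ccc(S(=O)(=O)N2CCC[C@@H](C(=O)NC3CN(C(=O)C4CC4)C3)C2)cc1`: in this assay compound 2 gives > 10000 nM, again a limit of the assay.
Compound 3 `CCOC(=O)[C@H]1CCN(S(=O)(=O)c2ccc(S(=O)(=O)N(CC)CC)cc2)C1`: in this assay compound 3 gives > 10000 nM, also a limit of the assay.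

Compound 2 thus stands exactly where the other two measured compounds stand: at the limit of the assay, with no number of its own. The whole set shown is made of limits, as the limit of > 10000 nM in this assay, at which 3 of the 3 values shown sit, records, and no two measured compounds differ in a single place, so no measured step tells how any change moves the read-out.

Compound 4 `CCN(CC)S(=O)(=O)c1ccc(S(=O)(=O)N2CCC[C@@H](C(=O)NC3CN(C(=O)NC(C)(C)C)C3)C2)cc1` differs from compound 2 in one place: (tert-butyl)amino in place of cyclopropyl on a carbonyl carbon. With every measured value sitting at the limit, there is nothing to size this change against. The step expected in this assay is none beyond the scatter, and the estimated step is a step that the limit leaves unreadable from compound 2 to compound 4. Compound 4 is accordingly expected to give about 15000 nM in this assay, with an estimated range from 5000 nM to 50000 nM, and it would most likely again be reported only as a limit rather than as a number.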

Compound 4, half-maximal inhibitory concentration: > 10000 nM
Compound 4 was reported as a limit; the forecaster's own chance of this, stated with the estimate: 75%; the middle value does not contradict the limit.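

In this assay compound 4 gives > 10000 nM, which is a limit of the assay. Compound 2 also sits at a limit, so no step can be read for the change of cyclopropyl to (tert-butyl)amino that separates compound 2 from compound 4. The compounds shown leave open whether any change to the shared core would give a measurable value in this assay.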